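The compounds below may be only part of what the source reports. "The series", "measured", "known", "first", "only" and "open" are said of these compounds alone.

Measured so far in a functional assay on HT-29 cells (Homo sapiens) for inhibition, read by luminescence and CellTiter-Glo, with a stated time of 24 h; on this read-out higher numbers stand for an effect only at larger amounts of compound and lower numbers for an effect already at smaller amounts:
Compound 1 `CN1C(=S)[C@@H](NC(=O)c2nc(Cc3ccccc3)n(C)n2)COc2ccccc21` gives 2.5 nM
Compound 2 `CCn1nc(C(=O)N[C@H]2COc3ccccc3N(C)C2=S)nc1Cc1ccccc1` gives 17 nM
Compound 3 `CCCCn1nc(C(=O)N[C@H]2COc3ccccc3N(C)C2=S)nc1Cc1ccccc1` gives 510 nM

Compound 3 has the highest number of the three, beyond the scatter from both others. The change to compound 4 `CCCCCn1nc(C(=O)N[C@H]2COc3ccccc3N(C)C2=S)nc1Cc1ccccc1` is methyl in place of hydrogen on a saturated chain carbon, four bonds along the chain from an aromatic nitrogen, with methyl in place of hydrogen on a saturated chain carbon, four bonds along the chain from an aromatic nitrogen. Two earlier changes on this chain bear on it: a 6.8-fold higher number from compound 1 to compound 2 (0.83 log units; beyond the scatter) and a 30-fold higher number from compound 2 to compound 3 (1.48 log units; beyond the scatter). Both went upward, and none of the three compounds goes against that trend, although the second step added an ethyl rather than a methyl. A further modest rise in this assay is therefore expected, as a 3.9-fold higher number from compound 3 to compound 4 (0.59 log units; beyond the scatter). For compound 4 the estimated value is 2000 nM, with an expected range of 600 nM to 8000 nM.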

Compound 4, half-maximal effective concentration: 805 nM
For compound 4 the middle estimate is 2.5-fold (0.40 log units) above the measured one; measured number inside the range.
By their numbers in this assay, from the lowest: compound 1; then compound 2; then compounds 3 and 4 (each within the scatter of the next).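

In this assay the rise along this chain no longer reads at the saturated chain carbon, four bonds along the chain from an aromatic nitrogen: a 1.6-fold higher number from compound 3 to compound 4 (0.20 log units; within the scatter). The large gaps stay with the shorter chains, shown by a 47-fold higher number from compound 2 to compound 4 (1.68 log units; beyond the scatter) and a 320-fold higher number from compound 1 to compound 4 (2.51 log units; beyond the scatter). Methyl in place of hydrogen counts for less here than on the core of compound 1: the same change on two cores in this assay, a 6.8-fold higher number (0.83 log units; beyond the scatter) from compound 1 to compound 2 and a 1.6-fold higher number (0.20 log units; within the scatter) from compound 3 to compound 4, 4.3-fold (0.63 log units) apart, beyond the scatter of two such steps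

On these data alone, whether a longer chain stays at the level of compounds 3 and 4 remains open. So does whether an amine or a carboxylic acid on this chain would bring the number back down.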